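Carbamate chain branching in a fluoropyrimidine nucleoside series

A few compounds are considered here, and "the series" means these few. Any claim that something is new, unique, unknown or untested is made for them only; others in the source may bear on it.

Two measured compounds share the core of compound 1 `CCCCCOC(=O)Nc1nc(=O)n([C@@H]2O[C@H](C)[C@H]3OC(=O)O[C@H]32)cc1F`; compound 2 `CCC(C)COC(=O)Nc1nc(=O)n([C@@H]2O[C@H](C)[C@@H](O)[C@H]2O)cc1F` carries a different sugar portion and a branched chain on the carbamate. In a functional assay on HeLa cells (Homo sapiens) for cytotoxicity, read by MTT assay, with a stated time of 3 days (a lower number here means a stronger inhibitor, a higher number a weaker inhibitor), compound 1 gives 80 ug/mL and compound 2 gives 90 ug/mL. The two numbers lie within the scatter of each other, so nothing separates the two compounds on this read-out; compound 1 merely holds the smaller of the two figures.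

Compound 3 `CC(C)CCOC(=O)Nc1nc(=O)n([C@@H]2O[C@H](C)[C@H]3OC(=O)O[C@H]32)cc1F` is not yet measured. It differs from compound 1 only in the carbamate chain: isopropyl in place of propyl on a saturated chain carbon, two bonds along the chain from an oxygen next to a carbonyl group. The chain keeps its length in atoms and its lack of donors and acceptors; only the branching position moves. Within the data shown here, no measured pair isolates this change, so the expected step has to be read from the general closeness of compound 1 and compound 2, whose chains already differ in branching without any separation beyond the scatter.

The expectation for the step from compound 1 to compound 3 in this assay is therefore a change of a 1.1-fold higher number from compound 1 to compound 3 (0.03 log units; within the scatter), which is to say none beyond the scatter. Compound 3 is estimated to give 85 ug/mL in this assay, within a range from 45 ug/mL to 160 ug/mL.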

Compound 3, half-maximal inhibitory concentration: 130 ug/mL
Estimate against measurement, compound 3: 1.5-fold (0.18 log units) below; low and high end bracket the measured number.
By their numbers in this assay, from the lowest: compounds 1, 2 and 3 (each within the scatter of the next).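

Among these compounds, compound 1 and compound 3 form the first pair that isolates this change. In this assay, pentyl to isopentyl, with isopropyl in place of propyl on a saturated chain carbon, two bonds along the chain from an oxygen next to a carbonyl group, gives a 1.6-fold higher number from compound 1 to compound 3 (0.21 log units; within the scatter) and so does not separate the two compounds. With the sugar portion held constant, this direct comparison shows that moving the branch to this carbon of the carbamate chain has no effect on this read-out that can be told from the scatter, though one pair sets no trend for the series. Nothing measured here gives a reason for this result or speaks to any property of either chain.

The compounds shown leave open whether a longer chain such as hexyl, or a chain ending in an amine or a carboxylic acid, would give a step beyond the scatter at this place. Among the compounds shown here, they also leave open how the same change from pentyl to isopentyl reads on the sugar portion of compound 2, for which no matched pair stands here.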